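Trifluoromethyl for Methyl on the Methoxy Group

This account rests on a few compounds, and the source may have more. Where it says the series, first, only, none or still open, it means among the compounds named here.

Measured so far:
compound 1 `Fc1ccccc1Nc1nc2nonc2nc1Nc1ccccc1`: 2200 nM
compound 2 `Fc1ccc(Nc2nc3nonc3nc2Nc2ccccc2F)cc1`: 2300 nM
compound 3 `COc1ccc(Nc2nc3nonc3nc2Nc2ccccc2F)cc1`: 1600 nM

In an assay on mitochondria from L6 cells (Rattus norvegicus) for activation, with a stated time of 90 min (a higher number here means that more compound is needed for the effect, a lower number that less compound is needed), compound 3 has the smallest of the three numbers, though the gaps to the others are within the scatter: a 1.4-fold lower number from compound 1 to compound 3 (0.14 log units; within the scatter) and a 1.4-fold lower number from compound 2 to compound 3 (0.16 log units; within the scatter). Compound 4 `Fc1ccccc1Nc1nc2nonc2nc1Nc1ccc(OC(F)(F)F)cc1` has not yet been measured in this assay. It differs from compound 3 in one place: trifluoromethyl in place of methyl on an oxygen on an aromatic ring. For the measured compounds named here, no measured step makes this same change; the nearest are the steps on the same ring, a 1.0-fold higher number from compound 1 to compound 2 (0.02 log units; within the scatter) and a 1.4-fold lower number from compound 1 to compound 3 (0.14 log units; within the scatter), both within the scatter, so hydrogen, fluoro and methoxy there have given no step beyond the scatter. The step of a 1.1-fold higher number from compound 3 to compound 4 (0.05 log units; within the scatter) is therefore expected to stay within the scatter. Compound 4 is expected to give 1800 nM, in the range 700 nM to 4500 nM.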

Compound 4, half-maximal effective concentration: 1300 nM
The estimate for compound 4 lay 1.4-fold (0.14 log units) above the measured number, within the range that was stated.
By their numbers in this assay, from the lowest: compounds 4, 3, 1 and 2 (each within the scatter of the next).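

In this assay the change on the oxygen itself also stays within the scatter (a 1.2-fold lower number from compound 3 to compound 4 (0.09 log units; within the scatter)). Trifluoromethoxy likewise shows no step beyond the scatter against fluoro (a 1.8-fold lower number from compound 2 to compound 4 (0.25 log units; within the scatter)) or hydrogen (a 1.7-fold lower number from compound 1 to compound 4 (0.23 log units; within the scatter)), so the four groups tried at this place on the ring cannot be told apart here. Nothing available explains this result.

From the compounds shown here alone, it stays open whether an amine or a carboxylic acid at this place would give a step beyond the scatter. Changes to the fluoro on the other ring, shared by all four compounds, also remain open.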